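The compounds below may be only part of what the source reports. "The series", "measured", "known", "first", "only" and "open" are said of these compounds alone.

Measured in a functional assay on the whole organism with Rattus norvegicus as the target (a higher number here means that more compound is needed for the effect, a lower number that less compound is needed), so far
Compound 1 `O=C(O)C(=O)Nc1nc(-c2cc(Cl)no2)cs1` gives > 30 mg/kg (a limit of the assay)
Compound 2 `COc1cc(-c2csc(NC(=O)C(=O)O)n2)on1` gives 8 mg/kg
Compound 3 `Cc1cc(-c2csc(NC(=O)C(=O)O)n2)on1` gives 6 mg/kg

Among the compounds with values here, compound 3 stands level with the only other exact number, that of compound 2 (8 mg/kg). Compound 4 `O=C(O)C(=O)Nc1nc(-c2cc(CO)no2)cs1` has hydroxy in place of hydrogen on a saturated chain carbon bound to an aromatic carbon, methyl to hydroxymethyl (hydroxy in place of hydrogen on a saturated chain carbon bound to an aromatic carbon). Within the data shown here, no measured step makes this change. The nearest steps swap the group it alters: a 1.3-fold lower number from compound 2 to compound 3 (0.12 log units; within the scatter) stays within the scatter, whereas an at least 5.0-fold lower number from compound 1 to compound 3 (0.69 log units; beyond the scatter) goes beyond it. The expected step is therefore small, tending to a higher number, and is estimated as a 1.7-fold higher number from compound 3 to compound 4 (0.22 log units; within the scatter). For compound 4 the expected value is 10 mg/kg, with an estimated range from 3 mg/kg to 30 mg/kg.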

Compound 4, dose for half-maximal effect: 0.7 mg/kg
The estimate for compound 4 lay 14-fold (1.15 log units) above the measured number; measured number outside the range, below it.
By their numbers in this assay, from the lowest: compound 4; then compounds 3 and 2 (each within the scatter of the next). At a limit, above all of these: compound 1.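

In this assay, within the data shown here, this place on the shared core had so far separated only chloro from the other two groups, while methoxy and methyl stayed within the scatter of each other. Hydroxy in place of hydrogen on the saturated chain carbon now goes beyond the scatter (an 8.6-fold lower number from compound 3 to compound 4 (0.93 log units; beyond the scatter)), and hydroxymethyl also stands apart from methoxy (an 11-fold lower number from compound 2 to compound 4 (1.06 log units; beyond the scatter)) and from chloro (an at least 42-fold lower number from compound 1 to compound 4 (1.63 log units; beyond the scatter)). The last of these steps is only a bound, as compound 1 stands at a limit of the assay: the limit of > 30 mg/kg in this assay, at which 1 of the 4 values shown sits. Going by these compounds, whether an aminomethyl, a methoxymethyl or a longer hydroxyalkyl chain here would give a number like that of compound 4 stays open.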